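A few compounds are considered here, and "the series" means these few. Any claim that something is new, unique, unknown or untested is made for them only; others in the source may bear on it.

Compound 1, `Cc1nnc(SCc2cc(=O)c3ccccc3o2)o1`, in a functional assay on LM7 cells (Homo sapiens) for cytotoxicity, read by MTT assay, with a stated time of 72 h (on this read-out lower numbers stand for stronger inhibition and higher numbers for weaker inhibition), gives only a limit of the assay, > 25000 nM.
Compound 2, `Nc1nnc(SCc2cc(=O)c3ccccc3o2)s1`, in this assay gives likewise only a limit, > 25000 nM.
Compound 3, `Cc1nnc(SCc2coc3ccccc3c2=O)o1`, in this assay gives 3500 nM.

Compound 1 and compound 3 are built from the same atoms joined differently; the difference between the two cores is not broken down here. Compound 4, `Nc1nnc(SCc2coc3ccccc3c2=O)s1`, has not yet been measured in this assay. It differs from compound 3 by 5-amino-1,3,4-thiadiazol-2-yl in place of 5-methyl-1,3,4-oxadiazol-2-yl on a sulfur. The same change, (5-amino-1,3,4-thiadiazol-2-yl in place of 5-methyl-1,3,4-oxadiazol-2-yl on a sulfur), separates compound 1 from compound 2, at the same place. There it made a step that the two limits leave unreadable from compound 1 to compound 2, because both values sit at the limit of > 25000 nM in this assay, at which 2 of the 3 values shown sit. The measured pair thus gives no size for this change, and only compound 3 offers a numbered starting point. The step from compound 3 to compound 4 in this assay is expected to be a 1.7-fold higher number from compound 3 to compound 4 (0.23 log units; within the scatter). The range is set wide; the one measured case of this change gave no readable size. Compound 4 is estimated at 6000 nM, between 1500 nM and 25000 nM.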

Compound 4, half-maximal inhibitory concentration: 730 nM
Estimate against measurement, compound 4: 8.2-fold (0.91 log units) above; the whole stated range lies above it.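

In this assay, putting 5-amino-1,3,4-thiadiazol-2-yl in place of 5-methyl-1,3,4-oxadiazol-2-yl on the sulfur gives a 4.8-fold lower number from compound 3 to compound 4 (0.68 log units; beyond the scatter), so on the core of compound 3 the change has a readable size that lies beyond the usual scatter. This single step shows what the change does on that core only, and it cannot show that the change carries over to another core, as the matching pair on the core of compound 1 offers no size to set beside it. That pair, compound 1 and compound 2, cannot be read because both compounds give only a limit of the assay and not a number: the limit of > 25000 nM in this assay, at which 2 of the 4 values shown sit.

The swap alters the ring and its substituent together, so the compounds shown leave open how much of the step belongs to the amino group and how much to the ring. As far as these compounds go, a group such as 5-methyl-1,3,4-thiadiazol-2-yl or 5-amino-1,3,4-oxadiazol-2-yl on the same sulfur would separate the two, and the effect of a longer chain in place of the methyl also remains open.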